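Aryl swap on the oxadiazole: compound 1 to compound 4

A few compounds are considered here, and "the series" means these few. Any claim that something is new, unique, unknown or untested is made for them only; others in the source may bear on it.

Compound 1 `Cc1cccc(-c2noc(C3CC(=O)N(c4ccc(F)cc4)C3)n2)n1` gives in an in vitro functional assay on HEK293-A cells for positive allosteric modulation of metabotropic glutamate receptor 5 (Homo sapiens), read by FLIPR and calcium flux (on this read-out lower numbers stand for an effect already at smaller amounts and higher numbers for an effect only at larger amounts of compound), only the limit > 10000 nM and no number. Compound 2 `Cc1cccc(-c2noc(C3CC(=O)N(c4ccc(Cl)cc4)C3)n2)n1`, with chloro in place of fluoro on an aromatic carbon, likewise returns only the limit > 10000 nM in this assay. The step that the two limits leave unreadable from compound 1 to compound 2 is unreadable, since both values sit at the limit of > 10000 nM in this assay, at which 2 of the 3 values shown sit. Compound 3 `Cc1ccc(N2CC(c3nc(-c4cccc(Cl)c4)no3)CC2=O)cc1` differs from compound 1 in two places; in this assay compound 3 gives 630 nM. Among the compounds with values here, no single step joins compound 3 to compound 1, so it shows only that a numbered value is reached with a 3-chlorophenyl group on the five-membered ring and a 4-methylphenyl group on the lactam nitrogen.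

Compound 4 `COc1cccc(-c2noc(C3CC(=O)N(c4ccc(F)cc4)C3)n2)c1` differs from compound 1 by 3-methoxyphenyl in place of 6-methylpyridin-2-yl on an aromatic carbon. Within the data shown here, no measured step touches this position, and the one measured step, from compound 1 to compound 2, is unreadable and concerns the other ring. The direction can only be toward a readable number, as compound 1 already stands at the limit; the size is open. The expected value for compound 4 in this assay is 3000 nM, with a range from 500 nM to 20000 nM, and a real chance of a second limit. This estimate implies a step of an at least 3.3-fold lower number from compound 1 to compound 4 (0.52 log units; beyond the scatter).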

Compound 4, half-maximal effective concentration: 1100 nM
The estimate for compound 4 lay 2.7-fold (0.44 log units) above the measured number; low and high end bracket the measured number.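

Within the data shown here, compound 4 is the first compound here to show that the aromatic group on the five-membered aromatic ring alone can bring a member of this series to a numbered value: 3-methoxyphenyl in place of 6-methylpyridin-2-yl gives an at least 9.0-fold lower number from compound 1 to compound 4 (0.95 log units; beyond the scatter) in this assay. The earlier compounds shown here could not show this, since the step from compound 1 to compound 2 cannot be read and compound 3 differs from compound 1 in two places. The size of the new step is only a lower bound, because compound 1 carries a limit and no number: the limit of > 10000 nM in this assay, at which 2 of the 4 values shown sit.

The change replaces a ring nitrogen and a methyl group in a single step, so the compounds shown do not separate the two, and 3-methylphenyl or 6-methoxypyridin-2-yl at this position would be needed to tell them apart. Also open, from the compounds shown here alone, is whether chloro in place of fluoro on the lactam aryl group gives a readable step when 3-methoxyphenyl sits on the five-membered aromatic ring.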